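From 3-methylphenyl to thiophen-2-yl on the carbonyl

The source may report more compounds than this note shows. Statements on the series, on what has been measured and on what is new or still open speak of the compounds shown alone.

Among the measured compounds shown here, in an ADME assay on L929 cells (Mus musculus) for cytotoxicity, read by resazurin assay, with a stated time of 72 h (a lower number here means a stronger inhibitor, a higher number a weaker inhibitor), compound 2 `Cc1cccc(C(=O)/C=C/c2ccc3c(c2)B(O)OC3)c1` gives 8.56 ug/mL, the only exact number so far. For compound 1 `COCOc1cccc(C(=O)/C=C/c2ccc3c(c2)B(O)OC3)c1`, > 10 ug/mL is a limit of the assay. For compound 3 `Cc1ccc(C(=O)/C=C/c2ccc3c(c2)B(O)OC3)cc1C`, > 10 ug/mL is also a limit.

Compound 4 `O=C(/C=C/c1ccc2c(c1)B(O)OC2)c1cccs1` differs from compound 2 at one place: thiophen-2-yl in place of 3-methylphenyl on a carbonyl carbon. For the measured compounds named here, two measured steps bear on this, an at least 1.1-fold lower number from compound 1 to compound 2 (0.06 log units; that floor lies within the scatter) and an at least 1.1-fold higher number from compound 2 to compound 3 (0.06 log units; that floor lies within the scatter). Each is only a floor, and neither replaces a whole ring, so they offer loose guidance. With no clear direction to follow, the expected change is a 1.1-fold higher number from compound 2 to compound 4 (0.02 log units; within the scatter), which means no step beyond the scatter. For compound 4 the estimate is 9 ug/mL, with an expected range from 4 ug/mL to 20 ug/mL.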

Compound 4, half-maximal inhibitory concentration: > 10 ug/mL
Compound 4 gave a limit, no number; the forecaster's own chance of this, stated with the estimate: 45%; middle value at least 1.1-fold (0.04 log units) from the limit.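

Among the compounds shown here, replacing the whole ring on the carbonyl, where the earlier steps changed only a group on that ring, gives an at least 1.1-fold higher number from compound 2 to compound 4 (0.06 log units; that floor lies within the scatter). For the compounds shown here, with thiophen-2-yl in place, compound 4 also yields only a limit in this assay, so compound 2 remains the one compound with an exact number. The true size of this step stays hidden because the readings stop at one shared point: the limit of > 10 ug/mL in this assay, at which 3 of the 4 values shown sit.

On these data alone, whether an amine or a carboxylic acid on the ring at this carbonyl would give an exact number remains open.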